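Working notes: from compound 2 to compound 3

The source may report more compounds than this note shows. Statements on the series, on what has been measured and on what is new or still open speak of the compounds shown alone.

Compound 1 `COc1cc(OC)c(OC)cc1/C=C/C(=O)c1cc(Cl)ccc1O`: > 150000 nM, a limit
Compound 2 `COc1cc(C(=O)/C=C/c2cc(OC)c(OC)cc2OC)ccc1O`: 95500 nM

Both entries come from a functional assay on MCF7 cells (Homo sapiens) for inhibition, read by MTT assay, with a stated time of 72 h; on this read-out higher numbers stand for weaker inhibition and lower numbers for stronger inhibition. Within the data shown here, compound 2 holds the only actual number so far, as the entry for compound 1 is a limit.

Compound 3 `COc1cc(OC)c(OC)cc1/C=C/C(=O)c1ccc(O)cc1` is still to be measured in this assay. It differs from compound 2 by hydrogen in place of methoxy on an aromatic carbon, ortho to a hydroxy group and meta to a large group (hydrogen in place of methoxy on an aromatic carbon).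

Among the measured compounds shown here, no measured pair shows this change, so the expectation rests on compound 2 at 95500 nM alone. No shift beyond the usual scatter is expected in either direction. The expected step of a 1.2-fold lower number from compound 2 to compound 3 (0.08 log units; within the scatter) is therefore small. For compound 3 the estimated value is 80000 nM, with an expected range of 30000 nM to 170000 nM.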

Compound 3, half-maximal inhibitory concentration: 182000 nM
For compound 3 the middle estimate is 2.3-fold (0.36 log units) below the measured one, and the stated range ends below it.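

In this assay, among these compounds, hydrogen in place of methoxy on an aromatic carbon, ortho to a hydroxy group and meta to a large group, gives a 1.9-fold higher number from compound 2 to compound 3 (0.28 log units; within the scatter), the first readable step. The two compounds therefore cannot be told apart in this assay, and this single pair gives no sign that the methoxy group at this position matters for the read-out. The step between compound 1 and compound 3 cannot be read, since the entry for compound 1 is a limit and not a number: the limit of > 150000 nM in this assay, at which 1 of the 3 values shown sits.

From the compounds shown here alone, only hydrogen and methoxy are compared at this position, so it remains open whether an amine, a carboxylic acid or a longer chain such as butoxy there would move the number beyond the scatter. Going by these compounds, whether the same exchange behaves alike on another core also remains open.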